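Replacing the phenyl group of compound 1

A few compounds are considered here, and "the series" means these few. Any claim that something is new, unique, unknown or untested is made for them only; others in the source may bear on it.

compound 1 `CCS(=O)(=O)Nc1ccc(Oc2ccccc2)c(-c2cn(C)c(=O)c3[nH]ccc23)c1` gives 3330 mL/min/kg
compound 2 `Cn1cc(-c2cc(S(N)(=O)=O)ccc2Oc2ccccc2)c2cc[nH]c2c1=O` gives 1320 mL/min/kg
compound 3 `Cn1cc(-c2cc(NS(C)(=O)=O)ccc2Oc2ccc(F)cc2Cl)c2cc[nH]c2c1=O` gives 317 mL/min/kg

In an ADME assay on microsomes from liver (Rattus norvegicus) for metabolic stability, read by HPLC, using NADPH, with stated times of 5 min and 60 min, tested at 10 uM (on this read-out lower numbers stand for slow clearance and higher numbers for fast clearance), compound 1 stands highest of the three with 3330 mL/min/kg and both other compounds lie lower. Compound 4 `CCS(=O)(=O)Nc1ccc(OC2CCC(N(C)C)CC2)c(-c2cn(C)c(=O)c3[nH]ccc23)c1` keeps the rest of compound 1 and changes one place (4-(dimethylamino)cyclohexyl in place of phenyl on an oxygen on an aromatic ring): 4-(dimethylamino)cyclohexyl in place of phenyl on an oxygen on an aromatic ring.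

Among the compounds with values here, only one measured step changes a single place (a 2.5-fold lower number from compound 1 to compound 2 (0.40 log units; beyond the scatter)). It is modest and concerns a different place, sulfamoyl in place of (ethylsulfonyl)amino on an aromatic carbon, so it bears on this change only indirectly. Compound 3 (317 mL/min/kg) differs from compound 1 in more than one place, so its value cannot be tied to any single group. Within the data shown here, no measured step replaces the phenyl itself.

Still, compound 1 sits at the top of the range, and compound 2 (1320 mL/min/kg) also lies lower, so a fall seems likelier than a rise. The expected change is a lower number of moderate size (a 2.8-fold lower number from compound 1 to compound 4 (0.44 log units; beyond the scatter)), though this estimate rests on little. For compound 4 the estimated clearance is 1200 mL/min/kg with 300 mL/min/kg to 3500 mL/min/kg as the expected span.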

Compound 4, clearance: < 45 mL/min/kg
Compound 4 gave a limit, no number; the forecaster's own chance of this, stated with the estimate: 3%; middle value at least 26-fold (1.42 log units) from the limit.
By their numbers in this assay, from the lowest: compound 3; then compound 2; then compound 1. At a limit, below all of these: compound 4.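

The change from phenyl to 4-(dimethylamino)cyclohexyl on this oxygen gives an at least 74-fold lower number from compound 1 to compound 4 (1.86 log units; beyond the scatter), which shows that the group at this position can move the clearance reading in this assay by a large amount. Within the data shown here, the only earlier step between compounds differing in one place, a 2.5-fold lower number from compound 1 to compound 2 (0.40 log units; beyond the scatter), is modest and concerns a different place, so it could not reveal this. The value of compound 4 is a limit of the assay, not a number, and the full size of the step therefore stays unknown: the limit of < 45 mL/min/kg in this assay, at which 1 of the 4 values shown sits.

The compounds shown leave open which part of the change carries the step, the ring that is no longer aromatic or the dimethylamino group that enters with it. As far as these compounds go, a plain cyclohexyl or a 4-(dimethylamino)phenyl on the same oxygen would separate these two parts, and it also remains open whether the same swap would give a similar step with the sulfamoyl group of compound 2 in place of the (ethylsulfonyl)amino group.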